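The compounds below may be only part of what the source reports. "The series", "measured", "known", "first", "only" and "open" are said of these compounds alone.

Working notes on the shared core in a functional assay on NCI-H460 cells (Homo sapiens) for cytotoxicity, read by MTT assay; a lower number here means a stronger inhibitor, a higher number a weaker inhibitor.

Compound 1 `Cc1ccccc1Nc1nc(C)c(C(=O)/C=C/c2ccccc2)s1` gives > 25000 nM, a limit of the assay rather than a number. Compound 2 `COc1cccc(/C=C/C(=O)c2sc(Nc3ccccc3C)nc2C)c1` gives > 25000 nM, again only a limit. Compound 3 `COc1cccc(/C=C/C(=O)c2sc(Nc3ccc(C)cc3)nc2C)c1` gives > 25000 nM, also a limit.

The change hydrogen in place of methoxy on an aromatic carbon produced a step that the two limits leave unreadable from compound 2 to compound 1, a step whose size cannot be read owing to the limit of > 25000 nM in this assay, at which 3 of the 3 values shown sit. The change 4-methylphenyl in place of 2-methylphenyl on a nitrogen on an aromatic ring produced a step that the two limits leave unreadable from compound 2 to compound 3, likewise unreadable owing to the limit of > 25000 nM in this assay, at which 3 of the 3 values shown sit. Nothing more than the three limits is known about how the series responds to either change.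

Compound 4 `Cc1ccc(Nc2nc(C)c(C(=O)/C=C/c3ccccc3)s2)cc1` has not been measured. It stands to compound 3 as compound 1 stands to compound 2: the difference is hydrogen in place of methoxy on an aromatic carbon, and the surroundings of the place are the same in both cases, so this is the same change as before. The two cores differ by 4-methylphenyl in place of 2-methylphenyl on a nitrogen on an aromatic ring.

The expected step that the limit leaves unreadable from compound 3 to compound 4 rests on the same change having left compound 1 at > 25000 nM, itself a limit. Compound 4 is therefore expected to give 40000 nM, estimated to fall between 15000 nM and 120000 nM, and most likely to be reported again as a limit rather than a number.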

Compound 4, half-maximal inhibitory concentration: > 25000 nM
Compound 4 gave a limit, no number (the forecaster's own chance of this, stated with the estimate: 85%); the middle value does not contradict the limit.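

Compound 4 gives > 25000 nM as a limit of the assay and not a number. No new step can be read from compound 3 to compound 4 or from compound 1 to compound 4, because all the compounds sit at the same limit: the limit of > 25000 nM in this assay, at which 4 of the 4 values shown sit. The compounds shown leave open whether hydrogen in place of methoxy or 4-methylphenyl in place of 2-methylphenyl changes the potency of the shared core in this assay at all.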